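Chloro to bromo swap on the benzyl ring of the thiazole amides

The compounds below may be only part of what the source reports. "The series", "measured", "known", "first", "only" and "open" are said of these compounds alone.

Measured so far:
- compound 1, `O=C(Nc1ncc(Cc2ccc(Cl)cc2)s1)c1ccc(F)cc1F`: "not toxic" (no number reported)
- compound 2, `O=C(Nc1ncc(Cc2ccc(Cl)cc2)s1)c1cccs1`: > 50000 nM

Two compounds of the series have been run in an ADME assay on HepG2 2.2.15 cells (Homo sapiens) for cytotoxicity; on this read-out higher numbers stand for lower toxicity in this test and lower numbers for higher toxicity in this test. Compound 1 `O=C(Nc1ncc(Cc2ccc(Cl)cc2)s1)c1ccc(F)cc1F` is recorded in this assay as "not toxic" (no number reported) without a number. Compound 2 `O=C(Nc1ncc(Cc2ccc(Cl)cc2)s1)c1cccs1` reaches only a limit of the test in this assay and is recorded as > 50000 nM. Among the compounds with values here, compound 2 therefore sits at the limit of > 50000 nM in this assay, at which 1 of the 2 values shown sits, so no single number is at hand for it and no step between measured compounds can be counted.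

Compound 3 `O=C(Nc1ncc(Cc2ccc(Br)cc2)s1)c1cccs1` differs from compound 2 by bromo in place of chloro on an aromatic carbon. The amide, the thiophene and the shared core are untouched. Within the data shown here, with compound 2 already at a limit in this assay and compound 1 without a number, no step gives a direction for the change. The expectation for this assay is a step that the limit leaves unreadable from compound 2 to compound 3, that is none beyond the scatter, and compound 3 is expected at 60000 nM with a range from 30000 nM to 120000 nM, most likely again reported as a limit.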

Compound 3, half-maximal cytotoxic concentration: > 50000 nM
Compound 3 was reported as a limit; the forecaster's own chance of this, stated with the estimate: 80%; the middle value does not contradict the limit.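

In this assay compound 2 gives > 50000 nM, a limit and not a number. Compound 3 gives > 50000 nM, also a limit, so no step can be read for bromo in place of chloro. The compounds shown leave open whether this swap changes the half-maximal cytotoxic concentration in this assay at all.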